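The compounds below may be only part of what the source reports. "The series", "measured", "known", "first", "only" and "open" are said of these compounds alone.

Measured compounds:
compound 1 `COc1cccc(/C=C/C(=O)c2ccccc2NC(=O)NS(=O)(=O)c2ccc(C)cc2)c1` — 23.2 ug/mL
compound 2 `COc1ccc(/C=C/C(=O)c2ccccc2NC(=O)NS(=O)(=O)c2ccc(C)cc2)cc1` — 28.1 ug/mL
compound 3 `Cc1ccc(S(=O)(=O)NC(=O)Nc2ccccc2C(=O)/C=C/c2cccc(O)c2)cc1` — 39.3 ug/mL

In an ADME assay on the whole organism for cytotoxicity, with Artemia salina as the target, with a stated time of 24 h (a lower number here means that less compound is needed, a higher number that more compound is needed for the effect), compound 1 gives 23.2 ug/mL, the lowest of the three numbers shown, but this standing carries little weight: the step of a 1.2-fold higher number from compound 1 to compound 2 (0.08 log units; within the scatter) and the step of a 1.7-fold higher number from compound 1 to compound 3 (0.23 log units; within the scatter) both sit within the scatter, as does a 1.4-fold higher number from compound 2 to compound 3 (0.15 log units; within the scatter). Compound 4 `Cc1ccc(S(=O)(=O)NC(=O)Nc2ccccc2C(=O)/C=C/c2ccccc2[N+](=O)[O-])cc1` differs from compound 1 in one place: 2-nitrophenyl in place of 3-methoxyphenyl on a double-bonded chain carbon bound to a double-bonded chain carbon. Among the measured compounds shown here, two measured steps bear on this change, since each also exchanges the group on a double-bonded chain carbon bound to a double-bonded chain carbon: a 1.2-fold higher number from compound 1 to compound 2 (0.08 log units; within the scatter) and a 1.4-fold higher number from compound 2 to compound 3 (0.15 log units; within the scatter), both within the scatter. For the measured compounds named here, no measured compound carries a 2-nitrophenyl group, so the data give no direct guide to it, and the reading rests on the small size of the aryl exchanges seen so far. The expected step for compound 4 in this assay is therefore a 1.1-fold higher number from compound 1 to compound 4 (0.05 log units; within the scatter), nothing beyond the scatter. Compound 4 is estimated at 26 ug/mL, with a range from 12 ug/mL to 55 ug/mL.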

Compound 4, concentration for half-maximal effect: 40.1 ug/mL
Beside the measured number, compound 4's estimate is 1.5-fold (0.19 log units) below it, within the range that was stated.
By their numbers in this assay, from the lowest: compounds 1, 2, 3 and 4 (each within the scatter of the next).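

In this assay the steps of a 1.7-fold higher number from compound 1 to compound 4 (0.24 log units; within the scatter) and a 1.4-fold higher number from compound 2 to compound 4 (0.15 log units; within the scatter) and a 1.0-fold higher number from compound 3 to compound 4 (0.01 log units; within the scatter) all lie within the scatter, so the 2-nitrophenyl group cannot be told apart from any of the three earlier aryl groups on a double-bonded chain carbon bound to a double-bonded chain carbon. The earlier compounds had shown this only for methoxy and hydroxy variants, whereas this change brings in a nitrogen and a double bond outside aromatic rings, and the number still stays within the scatter. No evidence is available on what underlies these numbers.

The compounds shown leave open whether an aromatic amine or a carboxylic acid on this ring would give a step beyond the scatter. They also leave open whether a longer saturated chain in place of the aryl group would do so.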